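Working notes on cytotoxicity within the series

The source may hold more compounds than are shown below. What is called first, only, known or untested is meant among the compounds shown, and "the series" means these compounds.

Compound 1 `Cc1ccccc1C(=O)c1cc(Cl)ccc1Oc1ccnc(Nc2ccc(C#N)cc2)n1` and compound 2 `N#Cc1ccc(Nc2nccc(Oc3ccc(C(=O)c4ccc(O)cc4)cc3)n2)cc1` share one core and differ only in the group it carries. In an ADME assay on MT4 cells (Homo sapiens) for cytotoxicity, read by MTT assay, with a stated time of 5 days (on this read-out higher numbers stand for lower toxicity in this test and lower numbers for higher toxicity in this test), compound 1 gives 28800 nM. In this assay compound 2 gives 19400 nM, which stands as the lowest of the two numbers recorded, a standing that means little since the gap to compound 1 lies within the usual scatter. For the measured compounds named here, no step between measured compounds is available for this series.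

Compound 3 `N#Cc1ccc(Nc2nccc(Oc3ccc(OCc4ccccc4)cc3)n2)cc1` has not yet been measured. It differs from compound 2 by a single change: benzyloxy in place of (4-hydroxyphenyl)carbonyl on an aromatic carbon. Going by the values given here, with no measured step to build on, the expectation rests only on compound 2 and on the modest size of the change. The expected step is small, a 1.4-fold lower number from compound 2 to compound 3 (0.14 log units; within the scatter), at most a slight move toward higher toxicity and quite possibly none beyond the scatter. Compound 3 is therefore estimated at 14000 nM in this assay, with a range from 5000 nM to 45000 nM covering the likely outcomes.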

Compound 3, half-maximal cytotoxic concentration: > 316000 nM
Compound 3 was reported as a limit; the forecaster's own chance of this, stated with the estimate: 15%; middle value at least 22-fold (1.35 log units) from the limit.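

At this position, para to a large group, the change from (4-hydroxyphenyl)carbonyl to benzyloxy is far from neutral in this assay: it gives an at least 16-fold higher number from compound 2 to compound 3 (1.21 log units; beyond the scatter), and the direction is toward lower toxicity in this test. Going by these compounds, compound 3 gives > 316000 nM, which is a limit of the assay and not a number, so the full size of the step stays unknown. Until now no step could be read in the series, and this one shows that a single change at this aromatic carbon can carry the read-out well beyond the scatter, with the high end of the series resting on one compound: the limit of > 316000 nM in this assay, at which 1 of the 3 values shown sits.

The compounds shown do not separate the parts of this exchange: the leaving group brings both a carbonyl and a hydroxyl, and the entering benzyloxy brings an ether oxygen and a different link to its ring, so any of these may account for the step. An unsubstituted benzoyl group, a benzylamino group or a carboxylic acid at the same place would be needed to tell these parts apart.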